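Two fluoro compounds and an ethoxy swap

The compounds below may be only part of what the source reports. "The series", "measured", "known", "first", "only" and "open" are said of these compounds alone.

Compound 1 `CC1(C)C=Cc2c(ccc(C(=O)/C=C/c3ccc(F)cc3)c2O)O1`: 158000 nM
Compound 2 `CC1(C)C=Cc2c(ccc(C(=O)/C=C/c3ccc(F)c(F)c3)c2O)O1`: 146000 nM

Both values come from an ADME assay on Vero cells (Chlorocebus sabaeus) for cytotoxicity, read by MTT assay, with a stated time of 72 h; on this read-out lower numbers stand for higher toxicity in this test and higher numbers for lower toxicity in this test. Compound 2 stands within the usual scatter of compound 1, so the two numbers cannot be told apart. The next structure is compound 3 `CCOc1cc(/C=C/C(=O)c2ccc3c(c2O)C=CC(C)(C)O3)ccc1F`, which keeps the shared core and changes one group: ethoxy in place of fluoro on an aromatic carbon. This is ethoxy in place of fluoro on an aromatic carbon, at a place ortho to a fluoro group and meta to a large group.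

Among the compounds with values here, only one measured step bears on this: a 1.1-fold lower number from compound 1 to compound 2 (0.03 log units; within the scatter). It is a different change, fluoro in place of hydrogen on an aromatic carbon, and it lies within the scatter. Going by that step, no change beyond the scatter is expected in this assay. Within the data shown here, no measured compound carries ethoxy, however, so the range has to stay wide. The expected result is a 1.1-fold lower number from compound 2 to compound 3 (0.05 log units; within the scatter). For compound 3 the estimated value is 130000 nM, with an expected range from 60000 nM to 260000 nM.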

Compound 3, half-maximal cytotoxic concentration: 185000 nM
Estimate against measurement, compound 3: 1.4-fold (0.15 log units) below; measured number inside the range.
By their numbers in this assay, from the lowest: compounds 2, 1 and 3 (each within the scatter of the next).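

In this assay, the swap of fluoro for ethoxy, which brings 3 heavy atoms in place of 1 and adds a hydrogen-bond acceptor, gives a 1.3-fold higher number from compound 2 to compound 3 (0.10 log units; within the scatter) and placing ethoxy where compound 1 has hydrogen gives a 1.2-fold higher number from compound 1 to compound 3 (0.07 log units; within the scatter) as well. This place on the aromatic ring, ortho to a fluoro group and meta to a large group, has now carried hydrogen, fluoro and ethoxy with every step within the scatter, whereas the earlier pair had shown only fluoro in place of hydrogen. Nothing measured here offers a reason for this flat result.

From the compounds shown here alone, whether an amine, a carboxylic acid or a longer chain such as butoxy at this place would also stay within the scatter remains open. Ethoxy is also shown only with a fluoro group ortho to it, so what it would do with that fluoro group replaced by hydrogen is open too.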